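The compounds below may be only part of what the source reports. "The series", "measured", "known", "first", "only" and "open" are said of these compounds alone.

Working notes on the series.

For the measured compounds named here, compound 1, `Cn1cncc1C(OCc1ccc(C#N)cc1-c1ccccc1)c1ccc(C#N)cc1`, is the only member with a number in a functional assay on NIH3T3 cells (Mus musculus) (on this read-out lower numbers stand for an effect already at smaller amounts and higher numbers for an effect only at larger amounts of compound), where compound 1 gives 140 nM. Compound 2, `Cn1cncc1C(OCc1ccc(C#N)cc1C#Cc1ccc(-c2ccccc2)cc1)c1ccc(C#N)cc1`, gives in this assay only a limit, > 0.1 nM. Compound 3, `Cn1cncc1C(OCc1ccc(C#N)cc1C#Cc1cccc(O)c1)c1ccc(C#N)cc1`, likewise gives in this assay only a limit, > 0.1 nM. Both of these sit at the limit of > 0.1 nM in this assay, at which 2 of the 3 values shown sit, so the step that the limit leaves unreadable from compound 1 to compound 3 and the step that the two limits leave unreadable from compound 2 to compound 3 cannot be sized.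

Compound 4, `Cn1cncc1C(OCc1ccc(C#N)cc1C#CCCc1ccccc1)c1ccc(C#N)cc1`, differs from compound 1 by 4-phenylbut-1-yn-1-yl in place of phenyl on an aromatic carbon. The two measured steps that touch this position, a step that the limit leaves unreadable from compound 1 to compound 3 and a step that the two limits leave unreadable from compound 2 to compound 3, are both unreadable, so they give no usable size or direction for the move from phenyl to a triple-bonded group. Compound 1 therefore remains the only anchor. The expected step of a 1.2-fold lower number from compound 1 to compound 4 (0.07 log units; within the scatter) is set at no change beyond the scatter, with a wide range to allow for the unread steps. Compound 4 is estimated at 120 nM in this assay, between 20 nM and 700 nM.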

Compound 4, half-maximal effective concentration: 130 nM
For compound 4 the middle estimate is 1.1-fold (0.03 log units) below the measured one, and the stated range covers the measured number.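

For the compounds shown here, the first readable step at this position in this assay is a 1.1-fold lower number from compound 1 to compound 4 (0.03 log units; within the scatter), with 4-phenylbut-1-yn-1-yl in place of phenyl. On this read-out, the aromatic carbon therefore accepts the larger group with its triple bond, and the phenyl ring carried further out on that chain, without a change beyond the scatter. The steps to compound 4 from compound 2 and from compound 3 cannot be read, because each of those two compounds is recorded only as a limit: the limit of > 0.1 nM in this assay, at which 2 of the 4 values shown sit.

The compounds shown leave open whether an amine or a carboxylic acid at the end of this chain, or a longer chain, would hold the number in this assay. They also leave open whether a saturated 4-phenylbutyl chain would do the same without the triple bond.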